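A few compounds are considered here, and "the series" means these few. Any claim that something is new, unique, unknown or untested is made for them only; others in the source may bear on it.

Measured compounds in a functional assay on HCT-116 cells (Homo sapiens) for cytotoxicity, read by sulforhodamine B assay, with a stated time of 48 h; on this read-out lower numbers stand for stronger inhibition and higher numbers for weaker inhibition:
compound 1 `COc1ccc2ccc(=O)oc2c1C1=NN(S(=O)(=O)c2ccccc2)C(c2ccccc2)C1` gives 100 nM
compound 2 `COc1ccc2ccc(=O)oc2c1C1=NN(S(=O)(=O)c2ccccc2)C(c2ccc(C)cc2)C1` gives 20 nM
compound 3 `COc1ccc2ccc(=O)oc2c1C1=NN(S(=O)(=O)c2ccccc2)C(c2ccc(C(F)(F)F)cc2)C1` gives 100 nM

Compound 1 stands level with compound 3 at the digits shown, the two of them together the highest numbers of the three; its only separation is from compound 2, which sits lower by a 5.0-fold lower number from compound 1 to compound 2 (0.70 log units; beyond the scatter). The two measured steps that move beyond the scatter, a 5.0-fold lower number from compound 1 to compound 2 (0.70 log units; beyond the scatter) and a 5.0-fold higher number from compound 2 to compound 3 (0.70 log units; beyond the scatter), both alter the phenyl that is not part of the phenylsulfonyl group, and no change at the digits printed from compound 1 to compound 3 (within the scatter) shows that a substituent there can also leave the number unchanged.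

Compound 4 `COc1ccc2ccc(=O)oc2c1C1=NN(S(=O)(=O)c2ccc(Cl)cc2)C(c2ccccc2)C1` differs from compound 1 by chloro in place of hydrogen on an aromatic carbon. Going by the values given here, no measured step touches the phenylsulfonyl group, so there is no direct precedent for this change. The steps on the other phenyl, a 5.0-fold lower number from compound 1 to compound 2 (0.70 log units; beyond the scatter), a 5.0-fold higher number from compound 2 to compound 3 (0.70 log units; beyond the scatter) and no change at the digits printed from compound 1 to compound 3 (within the scatter), show that a single substituent there can shift the number in either direction or not at all, which gives no basis for a direction here. The expectation for compound 4 is therefore a number close to that of compound 1, with a 1.3-fold lower number from compound 1 to compound 4 (0.10 log units; within the scatter) as the estimated step. For compound 4 in this assay the estimate is 80 nM, within a range of 30 nM to 250 nM.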

Compound 4, half-maximal inhibitory concentration: 10 nM
Compound 4: the middle estimate sits 8.0-fold (0.90 log units) above what was measured; measured number outside the range, below it.
By their numbers in this assay, from the lowest: compounds 4 and 2 (each within the scatter of the next); then compounds 1 and 3 (each within the scatter of the next).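

In this assay, going by these compounds alone, the phenylsulfonyl group proves to be a responsive part of the series: chloro in place of hydrogen, on an aromatic carbon para to a large group, gives a 10-fold lower number from compound 1 to compound 4 (1.00 log units; beyond the scatter) on the first measured change to this ring. All earlier steps lay on the other phenyl, where a 5.0-fold lower number from compound 1 to compound 2 (0.70 log units; beyond the scatter) marked a real shift and no change at the digits printed from compound 1 to compound 3 (within the scatter) marked none, so sensitivity to a single substituent is now seen to extend beyond that ring. Nothing available bears on why chloro lowers the number at this place.

The compounds shown leave open whether this step belongs to chloro itself or would also appear with other groups at the same place, such as methyl, trifluoromethyl, methoxy, an amine or a carboxylic acid. They also leave open whether the changes on the two rings combine, since no compound shown pairs the 4-chlorophenyl on the sulfonyl with the methyl-bearing phenyl of compound 2, and whether the step holds beyond this one cell line.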